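Taking the remaining acetyl off compound 2

The source may report more compounds than this note shows. Statements on the series, on what has been measured and on what is new or still open speak of the compounds shown alone.

In a functional assay on HL-60 cells (Homo sapiens) for cytotoxicity (a lower number here means a stronger inhibitor, a higher number a weaker inhibitor), compound 1 `COC(=O)/C=C/c1oc(=O)c(COC(C)=O)c(OC)c1CO` gives 650 nM and compound 2 `COC(=O)/C=C/c1oc(=O)c(CO)c(OC)c1COC(C)=O` gives 1040 nM while compound 3 `COC(=O)/C=C/c1oc(=O)c(COC(C)=O)c(OC)c1COC(C)=O` gives 520 nM so compound 2 lies within the scatter of both others. Compound 4 `COC(=O)/C=C/c1oc(=O)c(CO)c(OC)c1CO` differs from compound 2 in one place, with hydrogen in place of acetyl on an oxygen on a saturated carbon. Two measured steps run the opposite way, as a 1.3-fold lower number from compound 1 to compound 3 (0.10 log units; within the scatter) and as a 2.0-fold lower number from compound 2 to compound 3 (0.30 log units; within the scatter) and both stay within the scatter. No step beyond the scatter is therefore expected in this assay though a small move towards a higher number is possible. The estimate for compound 4 is 1300 nM with an expected range from 600 nM to 2800 nM as its limits. This expected value means a 1.3-fold higher number from compound 2 to compound 4 (0.10 log units; within the scatter) as the estimated step.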

Compound 4, half-maximal inhibitory concentration: > 50000 nM
Compound 4 was reported as a limit; the forecaster's own chance of this, stated with the estimate: 3%; middle value at least 38-fold (1.58 log units) away from the limit.
By their numbers in this assay, from the lowest: compounds 3, 1 and 2 (each within the scatter of the next). At a limit, above all of these: compound 4.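

In this assay, hydrogen in place of the last remaining acetyl gives an at least 48-fold higher number from compound 2 to compound 4 (1.68 log units; beyond the scatter) and an at least 76-fold higher number from compound 1 to compound 4 (1.88 log units; beyond the scatter). The result for compound 4, > 50000 nM, is a limit. The same change therefore stays within the scatter while another acetyl remains on the shared core, but not once none remains: the same change on two cores in this assay, a 1.3-fold lower number (0.10 log units; within the scatter) from compound 1 to compound 3 and an at least 48-fold lower number (1.68 log units; beyond the scatter) from compound 4 to compound 2, at least 38-fold (1.58 log units) apart, beyond the scatter of two such steps

The compounds shown leave open whether acetyl itself is needed, or whether a propionyl group or a methyl ether on the same oxygen would serve equally. They also leave open how far beyond its limit compound 4 lies.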